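Swapping Fluoro for Methoxy on a Biaryl Imidazoline

The source may report more compounds than this note shows. Statements on the series, on what has been measured and on what is new or still open speak of the compounds shown alone.

Measured so far in an assay for binding affinity to Adrenergic receptor alpha-1 (Rattus norvegicus); a lower number here means a stronger inhibitor, a higher number a weaker inhibitor:
compound 1, `Cc1c(NC2=NCCN2)cccc1-c1ccccc1`, gives 209 nM
compound 2, `Cc1cccc(-c2cccc(NC3=NCCN3)c2C)c1`, gives 166 nM
compound 3, `Cc1c(NC2=NCCN2)cccc1-c1cccc(F)c1`, gives 275 nM

Compound 3 carries the highest of the three numbers, yet its gaps to the others are small: a 1.3-fold higher number from compound 1 to compound 3 (0.12 log units; within the scatter) and a 1.7-fold higher number from compound 2 to compound 3 (0.22 log units; within the scatter), both within the scatter. Compound 4, `COc1cccc(-c2cccc(NC3=NCCN3)c2C)c1`, is not yet measured. Relative to compound 3 it carries methoxy in place of fluoro on an aromatic carbon, at the position meta to a large group. Among the compounds with values here, three steps bear on this spot: a 1.3-fold lower number from compound 1 to compound 2 (0.10 log units; within the scatter), a 1.3-fold higher number from compound 1 to compound 3 (0.12 log units; within the scatter) and a 1.7-fold higher number from compound 2 to compound 3 (0.22 log units; within the scatter); none left the scatter, so the spot has so far accepted hydrogen, methyl and fluoro alike. Within the data shown here, no methoxy analogue is among the measured compounds, so the expectation rests on that tolerance alone. Compound 4 is therefore expected to give about 230 nM, with a range from 100 nM to 550 nM. The step this implies, a 1.2-fold lower number from compound 3 to compound 4 (0.08 log units; within the scatter), is expected to stay within the scatter.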

Compound 4, inhibition constant: 43.7 nM
Compound 4: middle estimate off by 5.3-fold (0.72 log units), on the high side; measured number outside the range, below it.
By their numbers in this assay, from the lowest: compound 4; then compounds 2, 1 and 3 (each within the scatter of the next).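

In this assay, this position proves sensitive to what sits on it: methoxy stands apart from fluoro (a 6.3-fold lower number from compound 3 to compound 4 (0.80 log units; beyond the scatter)), from methyl (a 3.8-fold lower number from compound 2 to compound 4 (0.58 log units; beyond the scatter)) and from hydrogen (a 4.8-fold lower number from compound 1 to compound 4 (0.68 log units; beyond the scatter)). Hydrogen, methyl and fluoro all lie within the scatter of one another, so among these four groups only methoxy, the one with an oxygen and a hydrogen-bond acceptor, moves the number beyond it. Nothing shown here explains this difference. Whether the oxygen alone accounts for the step stays open, and a hydroxyl, an ethoxy or an amine on the same carbon would help to separate the possibilities.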